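The compounds below may be only part of what the source reports. "The series", "measured", "known", "first", "only" and "open" are said of these compounds alone.

The measured compounds in an ADME assay on Vero cells (Chlorocebus sabaeus) for cytotoxicity, read by resazurin assay, with a stated time of 72 h (on this read-out higher numbers stand for lower toxicity in this test and lower numbers for higher toxicity in this test), are:

compound 2, `CCCCN1C(=O)/C(=C\C(=O)C[C@@H]2O[C@H](COC(C)=O)[C@@H](OC(C)=O)[C@H](OC(C)=O)[C@H]2OC(C)=O)c2ccccc21`: 126000 nM
compound 3, `CCCCN1C(=O)/C(=C\C(=O)C[C@@H]2O[C@H](COC(C)=O)[C@@H](OC(C)=O)[C@H](OC(C)=O)[C@H]2OC(C)=O)c2cc(Cl)ccc21`: 88900 nM
compound 1, `CCCCN1C(=O)C(O)(CC(=O)C[C@@H]2O[C@H](COC(C)=O)[C@@H](OC(C)=O)[C@H](OC(C)=O)[C@H]2OC(C)=O)c2cc(Cl)ccc21`: "not determined" (no result reported)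

For the measured compounds named here, compound 3 gives the lowest of the two numbers, and the only other number, that of compound 2, sits close to it: the step of a 1.4-fold lower number from compound 2 to compound 3 (0.15 log units; within the scatter) lies within the scatter, so the two compounds cannot be told apart on this read-out. Compound 1 contributes no number and does not enter the comparison.

Compound 4 is `CC(=O)OC[C@H]1O[C@@H](CC(=O)/C=C2\C(=O)N(Cc3cccc(C)c3)c3ccc(Cl)cc32)[C@H](OC(C)=O)[C@@H](OC(C)=O)[C@@H]1OC(C)=O`. It differs from compound 3 in one place: 3-methylphenyl in place of propyl on a saturated chain carbon bound to an amide-type nitrogen in a ring. Going by the values given here, no measured pair in this set changes the group on the saturated chain carbon bound to the amide-type nitrogen in the ring; the single measured step concerns the chloro on the aromatic carbon and is within the scatter. Among the compounds with values here, there is therefore no step on record that bears directly on the change, and the one step that exists shows how little this read-out moved across the measured pair.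

For compound 4 the expected step from compound 3, a 1.3-fold lower number from compound 3 to compound 4 (0.10 log units; within the scatter), is accordingly small, with no direction that can be read from the data beyond the scatter. Compound 4 is estimated at 70000 nM in this assay, with a range from 25000 nM to 200000 nM.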

Compound 4, half-maximal cytotoxic concentration: 91000 nM
Compound 4: the middle estimate sits 1.3-fold (0.11 log units) below what was measured; low and high end bracket the measured number.
By their numbers in this assay, from the lowest: compounds 3, 4 and 2 (each within the scatter of the next).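

For the compounds shown here, the step at this place in this assay, a 1.0-fold higher number from compound 3 to compound 4 (0.01 log units; within the scatter), is the first on record for the group on the saturated chain carbon bound to the amide-type nitrogen in the ring, since the earlier step concerned only the chloro on the aromatic carbon. It shows that, with the rest of the structure held constant, propyl, with 3 carbons and no ring, and 3-methylphenyl, with 7 carbons and one six-membered aromatic ring, give numbers that cannot be told apart on this read-out, so for this one pair, adding the ring and the extra carbons leaves no readable mark. No measured evidence is available to account for this result.

The compounds shown leave open whether this holds for groups of another kind at the same place, such as an amine, a carboxylic acid or a longer chain, since the single pair offers only one ring-bearing group that carries only carbon. They also leave open whether the same indifference would appear with hydrogen in place of the chloro, or with free hydroxyl groups in place of the acetate esters on the shared core.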